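Acetylated glycoside oxindoles: Vero cytotoxicity working notes

The source may hold more compounds than are shown below. What is called first, only, known or untested is meant among the compounds shown, and "the series" means these compounds.

Measured in an ADME assay on Vero cells (Chlorocebus sabaeus) for cytotoxicity, read by resazurin assay, with a stated time of 72 h; on this read-out higher numbers stand for lower toxicity in this test and lower numbers for higher toxicity in this test:
compound 1 `CC(=O)OC[C@H]1O[C@@H](CC(=O)/C=C2\C(=O)N(Cc3cccc(C)c3)c3ccccc32)[C@H](OC(C)=O)[C@@H](OC(C)=O)[C@@H]1OC(C)=O` gives 72500 nM
compound 2 `CC(=O)OC[C@H]1O[C@@H](CC(=O)/C=C2\C(=O)Nc3ccccc32)[C@H](OC(C)=O)[C@@H](OC(C)=O)[C@@H]1OC(C)=O` gives 127000 nM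
compound 3 `CC(=O)OC[C@H]1O[C@@H](CC(=O)/C=C2\C(=O)N(Cc3cccc(C)c3)c3ccc(Cl)cc32)[C@H](OC(C)=O)[C@@H](OC(C)=O)[C@@H]1OC(C)=O` gives 91000 nM

Two single changes have been measured. From compound 1 to compound 2 the change is hydrogen in place of 3-methylbenzyl on an amide-type nitrogen in a ring; in this assay this gave a 1.8-fold higher number from compound 1 to compound 2 (0.24 log units; within the scatter). The other step, in the same assay, was a 1.3-fold higher number from compound 1 to compound 3 (0.10 log units; within the scatter).

Compound 4 `CC(=O)OC[C@H]1O[C@@H](CC(=O)/C=C2\C(=O)Nc3ccc(Cl)cc32)[C@H](OC(C)=O)[C@@H](OC(C)=O)[C@@H]1OC(C)=O` is not yet measured. It differs from compound 3 by hydrogen in place of 3-methylbenzyl on an amide-type nitrogen in a ring, the same change as from compound 1 to compound 2, made on the same place. The two cores differ by chloro in place of hydrogen on an aromatic carbon.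

For compound 4 in this assay the expected step is a 1.6-fold higher number from compound 3 to compound 4 (0.22 log units; within the scatter), which rests on the earlier instance having given a 1.8-fold higher number from compound 1 to compound 2 (0.24 log units; within the scatter). Compound 4 is therefore estimated at 150000 nM, with an expected range from 75000 nM to 300000 nM.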

Compound 4, half-maximal cytotoxic concentration: 122000 nM
For compound 4 the middle estimate is 1.2-fold (0.09 log units) above the measured one, and the stated range covers the measured number.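

In this assay, hydrogen in place of 3-methylbenzyl on the amide-type nitrogen in a ring gave a 1.3-fold higher number from compound 3 to compound 4 (0.13 log units; within the scatter), and the change carries from one core to the other within the scatter: the same change on two cores in this assay, a 1.8-fold higher number (0.24 log units; within the scatter) from compound 1 to compound 2 and a 1.3-fold higher number (0.13 log units; within the scatter) from compound 3 to compound 4, 1.3-fold (0.12 log units) apart, within the scatter of two such steps

Chloro in place of hydrogen on an aromatic carbon gave a 1.0-fold lower number from compound 2 to compound 4 (0.02 log units; within the scatter), and this change also carries across the two cores within the scatter: the same change on two cores in this assay, a 1.3-fold higher number (0.10 log units; within the scatter) from compound 1 to compound 3 and a 1.0-fold lower number (0.02 log units; within the scatter) from compound 2 to compound 4, 1.3-fold (0.12 log units) apart, within the scatter of two such steps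

Among these compounds, every step here lies within the scatter, so this agreement shows only that neither change moved the number beyond it on these two cores; it does not show that either change has a real effect, nor that any step size would hold on a further core.

The compounds shown leave open how this read-out responds to a longer chain or a chain carrying an amine on the ring nitrogen. Also open, from the compounds shown here alone, is the response to a carboxylic acid or methoxy group in place of chloro on the aromatic carbon.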